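This account rests on a few compounds, and the source may have more. Where it says the series, first, only, none or still open, it means among the compounds named here.

Working notes on the series.

Three compounds with a shared core and a sulfonyl-linked piperazine have been measured in an assay on CHO cells for displacement of a labelled ligand from adenosine receptor A1 (Homo sapiens), read by scintillation counting, with a stated time of 90 min, tested at 1 uM, in the presence of a further agent that is not named here; on this read-out higher numbers stand for more inhibition at the one concentration tested (going by the name of the read-out) and lower numbers for less inhibition. Compound 1, `CCCn1c(=O)[nH]c2nc(-c3ccc(S(=O)(=O)N4CCN(c5ccc(F)cc5)CC4)cc3)[nH]c2c1=O`, gives 14%. Compound 2, `CCCn1c(=O)[nH]c2nc(-c3ccc(S(=O)(=O)N4CCN(c5cccc(Br)c5)CC4)cc3)[nH]c2c1=O`, gives -1%. Compound 3, `CCCn1c(=O)[nH]c2nc(-c3ccc(S(=O)(=O)N4CCN(c5cccc(F)c5)CC4)cc3)[nH]c2c1=O`, gives 34%. On these numbers compound 1 stands second highest of the three: the nearest is compound 2, with a number 15 percentage points lower from compound 1 to compound 2 (beyond the scatter), and the furthest is compound 3, with a number 20 percentage points higher from compound 1 to compound 3 (beyond the scatter). Between the two outer compounds the step is a number 35 percentage points higher from compound 2 to compound 3 (beyond the scatter).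

Compound 4 is `CCCn1c(=O)[nH]c2nc(-c3ccc(S(=O)(=O)N4CCN(Cc5ccc(Br)cc5)CC4)cc3)[nH]c2c1=O`. Relative to compound 1 the change is 4-bromobenzyl in place of 4-fluorophenyl on an amine nitrogen in a ring. For the measured compounds named here, no measured step places a benzyl group on the ring nitrogen, so the only bearing comes from the bromine-containing compounds: the step of a number 15 percentage points lower from compound 1 to compound 2 (beyond the scatter) and the step of a number 35 percentage points higher from compound 2 to compound 3 (beyond the scatter) both show that the bromo compound sits lowest among the three. On that basis a modest lowering in this assay is expected, though it may not clear the scatter, giving an expected step of a number 8 percentage points lower from compound 1 to compound 4 (within the scatter). Compound 4 is therefore estimated at 6% in this assay, with a range from -15% to 28%.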

Compound 4, a percentage reported as inhibition, at one concentration (the size of the read-out at that concentration, not a potency): 31%
The estimate for compound 4 lay 25 percentage points below the measured number; the measured number lies above the stated range.
By their numbers in this assay, from the lowest: compound 2; then compound 1; then compounds 4 and 3 (each within the scatter of the next).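

In this assay the amine nitrogen in a ring accepts a 4-bromobenzyl group, with a number 17 percentage points higher from compound 1 to compound 4 (beyond the scatter) and with a number 32 percentage points higher from compound 2 to compound 4 (beyond the scatter), so the presence of bromine in the group on this nitrogen does not by itself go with the low number of compound 2. Set against the best aryl compound the change gives a number 3 percentage points lower from compound 3 to compound 4 (within the scatter), which leaves the 4-bromobenzyl group and the 3-fluorophenyl group indistinguishable here, even though the first has 8 heavy atoms and the 4-fluorophenyl group it replaces has 7. No measurement at hand accounts for these steps.

Compound 4 changes the halogen, its place on the aromatic ring and the link to the ring nitrogen all at once, so a plain benzyl group or a fluorobenzyl group would be needed to show which of these carries the step. As far as these compounds go, whether a longer chain such as phenylethyl, or a non-aromatic group such as cyclohexylmethyl, holds the number at this position also stays open.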